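The compounds below may be only part of what the source reports. "The series", "measured", "known", "first", "only" and "open" are said of these compounds alone.

In a functional assay on MDA-MB-231 cells (Homo sapiens) for cytotoxicity, read by MTT assay, with a stated time of 48 h (on this read-out higher numbers stand for weaker inhibition and lower numbers for stronger inhibition), compound 1 `CNC(=O)c1cc(Oc2cccc(NC(=S)Nc3ccc(Cl)cc3Cl)c2)ccn1` gives > 100000 nM, which is a limit of the assay rather than a number. Compound 2 `CNC(=O)c1cc(Oc2cccc(NC(=S)Nc3ccc(Cl)cc3)c2)ccn1` likewise reaches only a limit in this assay, > 100000 nM. The change from compound 2 to compound 1 is chloro in place of hydrogen on an aromatic carbon, and its size is a step that the two limits leave unreadable from compound 2 to compound 1 because both values sit at the limit of > 100000 nM in this assay, at which 2 of the 3 values shown sit. Among the compounds with values here, compound 3 `O=C(c1cc(Oc2cccc(NC(=S)Nc3cccc(C(F)(F)F)c3)c2)ccn1)N1CCCC1` is the only one with a number in this assay, 35400 nM; how its core differs from the core of compound 2 is not broken down here. Compound 4 `O=C(c1cc(Oc2cccc(NC(=S)Nc3ccc(Cl)c(C(F)(F)F)c3)c2)ccn1)N1CCCC1` has not yet been measured. It differs from compound 3 by chloro in place of hydrogen on an aromatic carbon. This is the same kind of change as from compound 2 to compound 1, but the surroundings differ: there the chloro entered ortho to a large group and meta to a chloro group, here ortho to a trifluoromethyl group and para to a large group. Since the measured pair gives no readable size, the expectation rests on compound 3 alone at 35400 nM, and a step of about a 1.4-fold lower number from compound 3 to compound 4 (0.15 log units; within the scatter) is expected, within the usual scatter. Compound 4 is therefore estimated at 25000 nM, between 9000 nM and 70000 nM.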

Compound 4, half-maximal inhibitory concentration: 40200 nM
Compound 4: the middle estimate sits 1.6-fold (0.21 log units) below what was measured, and the stated range covers the measured number.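

In this assay, adding chloro to the 3-(trifluoromethyl)phenyl group gives a 1.1-fold higher number from compound 3 to compound 4 (0.06 log units; within the scatter), so on this core the change has no effect that can be told apart from the usual scatter of repeated measurements. On the core of compound 2, the same change to give compound 1 cannot be read, because both compounds stand at a limit of the assay and not at a number: the limit of > 100000 nM in this assay, at which 2 of the 4 values shown sit. The series therefore offers one readable case of this change, ortho to a trifluoromethyl group, and it does not show whether the result carries over from one core to the other.

The compounds shown leave open whether an amine or a carboxylic acid in place of the chloro on that ring carbon would move the number beyond the scatter. It also stays open how much the core itself matters, as no two compounds shown carry the same substituted phenyl group on both cores.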